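Notes on the step from compound 3 to compound 4

The source may hold more compounds than are shown below. What is called first, only, known or untested is meant among the compounds shown, and "the series" means these compounds.

Measured in an ADME assay on L132 cells (Homo sapiens) for cytotoxicity, read by MTT assay, with a stated time of 72 h (on this read-out lower numbers stand for stronger inhibition and higher numbers for weaker inhibition), each value a limit and not a number:
- compound 1 `COc1ccc(C2=C(c3cc(OC)c(OC)c(OC)c3)C(=O)CC2O[SiH2]C(C)(C)C)cc1`: > 100 ug/mL
- compound 2 `COc1ccc(C2=C(c3cc(OC)c(OC)c(OC)c3)C(=O)CC2O[SiH2]C(C)(C)C)cc1OC`: > 100 ug/mL
- compound 3 `COc1cc(C2=C(c3cc(C)c(OC)c(C)c3)C(O[SiH2]C(C)(C)C)CC2=O)cc(OC)c1OC`: > 100 ug/mL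

Compound 3 gives > 100 ug/mL, which is a limit. Within the data shown here, the whole series so far stands at the limit of > 100 ug/mL in this assay, at which 3 of the 3 values shown sit.

Compound 4 `COc1ccc(C2=C(c3cc(OC)c(OC)c(OC)c3)C(=O)CC2O[SiH2]C(C)(C)C)cc1O` carries 3-hydroxy-4-methoxyphenyl in place of 4-methoxy-3,5-dimethylphenyl on a double-bonded ring carbon.

Among the measured compounds shown here, three measured steps bear on this change. Two exchange the aryl group on that same carbon: a step that the two limits leave unreadable from compound 1 to compound 3 and a step that the two limits leave unreadable from compound 2 to compound 3. The third is a step that the two limits leave unreadable from compound 1 to compound 2. None of them has a readable size, so the series gives no measured size or direction for such an exchange.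

No step beyond the scatter can therefore be forecast with any support, and a further limit is the likeliest result in this assay. The expected change is a number no higher from compound 3 to compound 4 (the limit leaves the size open), with no firm direction.

For compound 4 the estimated value is 100 ug/mL, with an expected range of 30 ug/mL to 200 ug/mL.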

Compound 4, half-maximal inhibitory concentration: < 1 ug/mL
Compound 4 ended at the assay's limit (the forecaster's own chance of this, stated with the estimate: 70%); at least 100-fold (2.00 log units) between middle value and limit.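

The earlier steps shown here among compound 1, compound 2 and compound 3 cannot be read, so this aryl group on the double-bonded ring carbon gains its first measured sizes here in this assay. Adding a hydroxy to this aryl group gives an at least 100-fold lower number from compound 1 to compound 4 (2.00 log units; beyond the scatter) and hydrogen in place of methyl on an oxygen on an aromatic ring gives an at least 100-fold lower number from compound 2 to compound 4 (2.00 log units; beyond the scatter) so a single free hydroxy separates compound 4 from its closest neighbours. The wider exchange of 4-methoxy-3,5-dimethylphenyl for 3-hydroxy-4-methoxyphenyl gives an at least 100-fold lower number from compound 3 to compound 4 (2.00 log units; beyond the scatter) and all three sizes rest on limits, so they are bounds only.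

The compounds shown leave open how far the true value of compound 4 lies past its limit. They also leave open whether an amine or a carboxylic acid in place of that hydroxy would give a similar step.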